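The source may report more compounds than this note shows. Statements on the series, on what has been measured and on what is new or still open speak of the compounds shown alone.

In a functional assay on L1210 cells (Mus musculus) for antiproliferative activity, read by cell counting, with a stated time of 2 days (on this read-out lower numbers stand for stronger inhibition and higher numbers for weaker inhibition), compound 1 `COc1ccc(Nc2nc(N)c(C(=O)c3ccccc3)s2)cc1` gives 850 nM. Compound 2 `Nc1nc(Nc2ccc(F)cc2)sc1C(=O)c1ccccc1` returns only a limit of the assay, > 10000 nM, and no number; that is the limit of > 10000 nM in this assay, at which 1 of the 2 values shown sits. Compound 3 `Cc1ccc(Nc2nc(N)c(C(=O)c3ccccc3)s2)cc1` keeps the shared core and replaces the 4-fluorophenyl of compound 2 with 4-methylphenyl: methyl in place of fluoro on an aromatic carbon. This puts methyl in place of fluoro on an aromatic carbon, para to a large group.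

Going by the values given here, one measured step bears on this change. It is an at least 11-fold higher number from compound 1 to compound 2 (1.07 log units; beyond the scatter), and it was large, with fluoro in place of methoxy at the site that changes again here. Read in reverse, that step suggests that removing the fluoro could bring back measurable inhibition. However, methyl is not methoxy, so the only guide to the size of the gain is compound 1 at 850 nM. A large move toward lower numbers is therefore expected, though compound 3 could also stay at the limit. The expected change is an at least 5.0-fold lower number from compound 2 to compound 3 (0.69 log units; beyond the scatter). For compound 3 the estimate is 2000 nM, with an expected range of 400 nM to 10000 nM.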

Compound 3, half-maximal inhibitory concentration: 2800 nM
For compound 3 the middle estimate is 1.4-fold (0.15 log units) below the measured one, within the range that was stated.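

In this assay, the change from 4-fluorophenyl to 4-methylphenyl returns the series to a measurable value, with an at least 3.5-fold lower number from compound 2 to compound 3 (0.55 log units; beyond the scatter). The fluoro compound is therefore not simply followed by any replacement of methoxy at the limit: methyl, a group with no hydrogen-bond donor or acceptor, also gives a number at this place. Methyl does not fully match methoxy, however, with a 3.3-fold higher number from compound 1 to compound 3 (0.52 log units; beyond the scatter), so the three groups now separate at this one position, with methoxy giving the lowest number, methyl a higher one, and fluoro no number at all; compound 2 stands at a limit of the assay, so the step from it is only a lower bound on the true change: the limit of > 10000 nM in this assay, at which 1 of the 3 values shown sits.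

Going by these compounds, whether chloro, an amine or a longer chain such as ethoxy in this same place would join methoxy and methyl among the measurable compounds or fall with fluoro at the limit remains open. The compounds shown also leave open whether this order of methoxy, methyl and fluoro holds when the shared core is changed elsewhere.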